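Replacing a trifluoromethoxy phenyl with an ethoxy-fluoro phenyl

The source may hold more compounds than are shown below. What is called first, only, known or untested is meant among the compounds shown, and "the series" means these compounds.

Compound 2 `COc1cc(Nc2nc3cccc(-c4ccccc4OC(F)(F)F)c3o2)cc(OC)c1OC` sits at the limit of an assay on BAF cells for inhibition of ribosomal protein S6 kinase alpha-2 (Mus musculus); on this read-out lower numbers stand for stronger inhibition and higher numbers for weaker inhibition: in this assay compound 2 gives > 20000 nM, which is a limit and not a number, as recorded in the limit of > 20000 nM in this assay, at which 1 of the 2 values shown sits. Compound 1 `COc1ccccc1-c1cccc2nc(Nc3cc(OC)c(OC)c(OC)c3)oc12` carries a methoxy where compound 2 carries a trifluoromethoxy; in this assay compound 1 gives 5700 nM. The step of an at least 3.5-fold higher number from compound 1 to compound 2 (0.54 log units; beyond the scatter) is the only measured one and it bears directly on the change that follows. Compound 3 `CCOc1cccc(F)c1-c1cccc2nc(Nc3cc(OC)c(OC)c(OC)c3)oc12` differs from compound 2 by 2-ethoxy-6-fluorophenyl in place of 2-(trifluoromethoxy)phenyl on an aromatic carbon. Going by the values given here, an ethoxy resembles the methoxy of compound 1 more than the trifluoromethoxy of compound 2, while the added fluorine has no measured counterpart here, so a return toward the number of compound 1 is expected, though with wide uncertainty. Compound 3 is therefore estimated at 9000 nM in this assay, between 2500 nM and 30000 nM, which would be expected to mean an at least 2.2-fold lower number from compound 2 to compound 3 (0.34 log units; beyond the scatter).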

Compound 3, half-maximal inhibitory concentration: 10800 nM
For compound 3 the middle estimate is 1.2-fold (0.08 log units) below the measured one; low and high end bracket the measured number.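

The change to 2-ethoxy-6-fluorophenyl on this aromatic carbon gives an at least 1.8-fold lower number from compound 2 to compound 3 (0.26 log units; that floor lies within the scatter), and the full size of this step cannot be read because compound 2 sits at a limit: the limit of > 20000 nM in this assay, at which 1 of the 3 values shown sits.

The second comparison gives a 1.9-fold higher number from compound 1 to compound 3 (0.28 log units; within the scatter), so in this assay this position takes the ethoxy and the fluorine together without a step beyond the scatter from the 2-methoxyphenyl group. Going by these compounds alone, of the two changes made to compound 1, only the one leading to compound 2, with its trifluoromethoxy, gives a step beyond the scatter.

From the compounds shown here alone, the ethoxy and the fluorine enter together, so the share of each in this result stays open. Also open, going by these compounds, is whether a different kind of group on this phenyl ring, such as an amine or a carboxylic acid, would give a lower number.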